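Second chloro on the urea phenyl of compound 3

The source may hold more compounds than are shown below. What is called first, only, known or untested is meant among the compounds shown, and "the series" means these compounds.

Among the three compounds measured in a functional assay on HT-29 cells (Homo sapiens) for cytotoxicity, read by MTT assay, with a stated time of 72 h (a lower number here means a stronger inhibitor, a higher number a weaker inhibitor), compound 3 `CCN(CC)CCCNc1nc(-c2ccc(NC(=O)Nc3ccc(Cl)cc3)cc2)nc2c(Cl)c(Cl)sc12` stands lowest: compound 3 gives 250 nM in this assay. Its nearest neighbour is compound 2 `CCN(CC)CCCNc1nc(-c2ccc(NC(=O)Nc3ccccc3)cc2)nc2c(Cl)c(Cl)sc12`, which gives 820 nM in this assay, and the furthest is compound 1 `CN(C)CCNc1nc(-c2ccc(NC(=O)Nc3ccc(Cl)cc3Cl)cc2)nc2c(Cl)c(Cl)sc12`, which gives 1280 nM in this assay. The one single-point step shown is a 3.3-fold lower number from compound 2 to compound 3 (0.52 log units; beyond the scatter), where a chloro replaced a hydrogen on the urea phenyl.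

Compound 4 `CCN(CC)CCCNc1nc(-c2ccc(NC(=O)Nc3ccc(Cl)cc3Cl)cc2)nc2c(Cl)c(Cl)sc12` has not yet been measured in this assay. It differs from compound 3 by chloro in place of hydrogen on an aromatic carbon, so that the 4-chlorophenyl becomes a 2,4-dichlorophenyl. Within the data shown here, no measured step reports this exact change with the same amine chain. Compound 1 carries the same 2,4-dichlorophenyl but a different amine chain, and its value is the highest of the three; compound 2 and compound 3 show that the first chloro brought a gain. Taken together, the second chloro is expected to bring no step beyond the scatter, or a small rise, for compound 4, with the step from compound 3 read as a 1.6-fold higher number from compound 3 to compound 4 (0.20 log units; within the scatter). Compound 4 is therefore estimated at 400 nM in this assay, within a range from 150 nM to 1200 nM.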

Compound 4, half-maximal inhibitory concentration: 1230 nM
Beside the measured number, compound 4's estimate is 3.1-fold (0.49 log units) below it, outside the stated range (above it).
By their numbers in this assay, from the lowest: compound 3; then compounds 2, 4 and 1 (each within the scatter of the next).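

In this assay the position ortho to a large group on the urea phenyl does not repeat the gain of the first chloro: where that chloro gave a 3.3-fold lower number from compound 2 to compound 3 (0.52 log units; beyond the scatter) on going to the 4-chlorophenyl, the second chloro, leading to the 2,4-dichlorophenyl, gives a 4.9-fold higher number from compound 3 to compound 4 (0.69 log units; beyond the scatter) and takes back what was gained. Taken as a whole, the change from phenyl to 2,4-dichlorophenyl gives a 1.5-fold higher number from compound 2 to compound 4 (0.18 log units; within the scatter) and cannot be told apart from no change, so the two chloro groups together bring no readable gain here. With the 2,4-dichlorophenyl in place on both compounds, the swap of the amine chain gives a 1.0-fold lower number from compound 1 to compound 4 (0.02 log units; within the scatter) and also cannot be told apart from no change, which ties the high value of compound 1 to its 2,4-dichlorophenyl and not to its dimethylamino chain.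

Nothing shown here offers a reason for the effect of this second chloro.

The compounds shown leave open whether a fluoro or a methoxy group in place of that chloro would behave the same way, and whether a longer amine chain would alter the result.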